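Sulfonamide in place of oxolanylmethyl: cytotoxicity outlook

A few compounds are considered here, and "the series" means these few. Any claim that something is new, unique, unknown or untested is made for them only; others in the source may bear on it.

Measured so far:
compound 1 `COc1ccc([C@H]2CC(=O)N(c3cccc(N)c3C)C2)cc1OC1CCCC1`, in a functional assay on HEK293 cells (Homo sapiens) for cytotoxicity; on this read-out higher numbers stand for lower toxicity in this test and lower numbers for higher toxicity in this test: > 10000 nM, a limit of the test rather than a number.
compound 2 `COc1ccc([C@H]2CC(=O)N(c3cccc(NCC4CCOC4)c3)C2)cc1OC1CCCC1`, in this assay: > 10000 nM, likewise a limit of the test rather than a number.

Compound 2 therefore stands at the boundary of what this assay reports; no number is known for it. Compound 1 stands at the same boundary, so the two values shown cannot be ordered against each other, and the limit of > 10000 nM in this assay, at which 2 of the 2 values shown sit, is all the series offers. For the measured compounds named here, no pair of measured compounds differs in a single place, so no measured step size exists here.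

Compound 3 `COc1ccc([C@H]2CC(=O)N(c3cccc(NS(=O)(=O)c4c(F)cccc4F)c3)C2)cc1OC1CCCC1` is the next compound to be measured. Relative to compound 2 the change is (2,6-difluorophenyl)sulfonyl in place of (oxolan-3-yl)methyl on a nitrogen on an aromatic ring.

With both values sitting at the limit, the expected step that the limit leaves unreadable from compound 2 to compound 3 is none beyond the scatter, and the most likely outcome is again a limit rather than a number. Compound 3 is estimated at 15000 nM, with a range from 5000 nM to 50000 nM.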

Compound 3, half-maximal cytotoxic concentration: > 10000 nM
Compound 3 was reported as a limit; the forecaster's own chance of this, stated with the estimate: 75%; the middle value is on the limit's open side.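

In this assay compound 3 gives > 10000 nM, a limit of the test and not a number. No step from compound 2 to compound 3 can be read, and the series offers only this: the limit of > 10000 nM in this assay, at which 3 of the 3 values shown sit.

Going by these compounds, how the (2,6-difluorophenyl)sulfonyl and (oxolan-3-yl)methyl groups compare in this assay stays open, as does any numerical value for these compounds.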